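The source may report more compounds than this note shows. Statements on the series, on what has been measured and on what is new or still open speak of the compounds shown alone.

Measured compounds in an ADME assay on HepG2 cells (Homo sapiens) for cytotoxicity, read by CellTiter-Glo and ATP content, with a stated time of 72 h; on this read-out lower numbers stand for an effect already at smaller amounts and higher numbers for an effect only at larger amounts of compound:

- compound 1, `CS(=O)(=O)c1ccc(C(=O)N2CCC(C(=O)N3CCN(c4ccc(F)cc4)CC3)CC2)cc1[N+](=O)[O-]`; its value is a limit of the assay, > 27000 nM
- compound 2, `CC(C)N(C(=O)CCNC(=O)c1ccc(S(C)(=O)=O)c([N+](=O)[O-])c1)C(C)C`; its value is likewise a limit of the assay, > 27000 nM

Compound 2 stands at the upper edge of what this assay reports: no number, only a limit, and the same holds for the other measured compound, so both sit at the limit of > 27000 nM in this assay, at which 2 of the 2 values shown sit. For the measured compounds named here, no step between two measured compounds is known, and nothing in the two values ranks compound 1 against compound 2.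

The next compound in the series is compound 3, `CS(=O)(=O)c1ccc(C(=O)NCCC(=O)N2CCc3ccccc3C2)cc1[N+](=O)[O-]`. From compound 2 it differs at one place: 1,2,3,4-tetrahydroisoquinolin-2-yl in place of diisopropylamino on a carbonyl carbon. The part of the molecule carrying the sulfonyl, the nitro group and the amide chain is unchanged.

With both measured values sitting at the limit, the expectation for this change is no step beyond the scatter, and compound 3 is expected to show a step that the limit leaves unreadable from compound 2 to compound 3 against compound 2. Compound 3 is estimated at 40000 nM in this assay, with a range from 15000 nM to 100000 nM, most probably reported again as a limit rather than a number.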

Compound 3, half-maximal effective concentration: > 27000 nM
Compound 3: a limit, no number (the forecaster's own chance of this, stated with the estimate: 80%); the middle value lies beyond the limit too.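

Compound 3 gives > 27000 nM in this assay, a limit of the assay and not a number. No step can be read from compound 2 to compound 3, since neither has a number: the limit of > 27000 nM in this assay, at which 3 of the 3 values shown sit.

The compounds shown leave open whether 1,2,3,4-tetrahydroisoquinolin-2-yl in place of diisopropylamino shifts the value at all, and at what concentration any effect would appear.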